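The compounds below may be only part of what the source reports. "The series", "measured", "known", "first", "only" and "open" are said of these compounds alone.

Of the compounds shown here, two built on the same core have been measured so far. Compound 1, `O=[N+]([O-])c1ccc(-n2cc(-c3ccc(C(F)(F)F)cc3)cn2)cc1`, gives 7150 nM in a functional assay on Bel-7402 cells (Homo sapiens) for cytotoxicity, read by MTT assay, with a stated time of 48 h; a higher number here means a weaker inhibitor, a lower number a stronger inhibitor. Compound 2, `O=[N+]([O-])c1ccc(-n2cc(-c3cc(C(F)(F)F)cc(C(F)(F)F)c3)cn2)cc1`, gives 7390 nM in this assay. Compound 1 is the compound this piece follows; the gap between it and compound 2 lies within the usual scatter of such measurements, so the two cannot be told apart on these numbers. Compound 3, `O=[N+]([O-])c1ccc(-c2cnn(-c3ccc([N+](=O)[O-])cc3)c2)cc1`, has not yet been measured. It differs from compound 1 in one place: nitro in place of trifluoromethyl on an aromatic carbon. For the measured compounds named here, no pair of measured compounds shows what this swap does, and the only pair in hand shows no movement beyond the scatter. The step that is expected is a 1.0-fold lower number from compound 1 to compound 3 (0.01 log units; within the scatter), small and without a clear direction. Compound 3 is therefore expected to give about 7000 nM in this assay, within a range from 2500 nM to 20000 nM.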

Compound 3, half-maximal inhibitory concentration: 9480 nM
Estimate against measurement, compound 3: 1.4-fold (0.13 log units) below; the range from low to high includes it.
By their numbers in this assay, from the lowest: compounds 1, 2 and 3 (each within the scatter of the next).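

In this assay the change to nitro in place of trifluoromethyl on this aromatic carbon gives a 1.3-fold higher number from compound 1 to compound 3 (0.12 log units; within the scatter) and so no movement that can be told apart from the scatter. For the compounds shown here, this is the first direct reading of a change at this position: the entering group has hydrogen-bond acceptors and fewer heavy atoms than trifluoromethyl, yet the two compounds cannot be separated on their numbers. No measurement at hand accounts for this result.

Nitro and trifluoromethyl both have no hydrogen-bond donors and no net charge, and it remains open whether an amine or a carboxylic acid on this carbon would move the number beyond the scatter. Also open, going by these compounds, is what the nitro group shared by all three compounds contributes, and whether a nitrile or a methoxy group in its place would change the reading.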